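Varying the aryl group on the triazole ring: compound 4

This account rests on a few compounds, and the source may have more. Where it says the series, first, only, none or still open, it means among the compounds named here.

Compound 1 `N#CC1=C(N)Oc2c(N)cc3nc4ccccc4nc3c2C12C(=O)N(Cc1cnnn1-c1cccc(C(F)(F)F)c1)c1ccccc12`: 5400 nM
Compound 2 `CCOc1ccc(-n2nncc2CN2C(=O)C3(C(C#N)=C(N)Oc4c(N)cc5nc6ccccc6nc5c43)c3ccccc32)cc1`: > 50000 nM
Compound 3 `Cc1cc(C)cc(-n2nncc2CN2C(=O)C3(C(C#N)=C(N)Oc4c(N)cc5nc6ccccc6nc5c43)c3ccccc32)c1`: 31200 nM

In a functional assay on A549 cells (Homo sapiens) for antiproliferative activity, read by MTT assay, with a stated time of 48 h (a higher number here means a weaker inhibitor, a lower number a stronger inhibitor), compound 3 gives the highest of the two numbers; its nearest neighbour is compound 1, which gives 5400 nM. For compound 2 only a limit of the assay is known, > 50000 nM, and (the limit of > 50000 nM in this assay, at which 1 of the 3 values shown sits). Compound 4 `N#CC1=C(N)Oc2c(N)cc3nc4ccccc4nc3c2C12C(=O)N(Cc1cnnn1-c1ccc(Cl)cc1[N+](=O)[O-])c1ccccc12` differs from compound 3 in one place: 4-chloro-2-nitrophenyl in place of 3,5-dimethylphenyl on an aromatic nitrogen.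

The measured steps all change the same aryl group: a 5.8-fold higher number from compound 1 to compound 3 (0.76 log units; beyond the scatter), an at least 9.2-fold higher number from compound 1 to compound 2 (0.96 log units; beyond the scatter) and an at least 1.6-fold lower number from compound 2 to compound 3 (0.20 log units; that floor lies within the scatter). None of them introduces the 4-chloro-2-nitrophenyl group, so the direction for compound 4 is open; the sizes seen are modest. Compound 4 is therefore expected to sit near compound 3, with a 1.6-fold lower number from compound 3 to compound 4 (0.19 log units; within the scatter) and an estimate of 20000 nM between 5000 nM and 60000 nM.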

Compound 4, half-maximal inhibitory concentration: > 50000 nM
Compound 4 gave a limit, no number; the forecaster's own chance of this, stated with the estimate: 25%; at least 2.5-fold (0.39 log units) between middle value and limit.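

In this assay compound 4 gives only a limit, > 50000 nM. Replacing 3-(trifluoromethyl)phenyl with 4-chloro-2-nitrophenyl gives an at least 9.2-fold higher number from compound 1 to compound 4 (0.96 log units; beyond the scatter), whereas the floor of an at least 1.6-fold higher number from compound 3 to compound 4 (0.20 log units; that floor lies within the scatter) does not separate this group from 3,5-dimethylphenyl. The step between the two limits cannot be read, and a second aryl group now stops at the same limit: the limit of > 50000 nM in this assay, at which 2 of the 4 values shown sit.

The compounds shown leave open whether the chlorine or the nitro group alone would give a readable number. They also leave open how an amine or a carboxylic acid on this aryl ring would compare with 3-(trifluoromethyl)phenyl.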